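Fluorine walk on the triazole phenyl of aryl ether amides

This account rests on a few compounds, and the source may have more. Where it says the series, first, only, none or still open, it means among the compounds named here.

The series rests on a shared core carried by compound 1 `Cc1c(C(=O)Nc2ccc(Oc3ccnc4[nH]ccc34)c(F)c2)nnn1-c1ccccc1` and compound 2 `Cc1c(C(=O)Nc2ccc(Oc3ccnc4[nH]ccc34)c(F)c2)nnn1-c1ccccc1F`. In a functional assay on HT-29 cells (Homo sapiens) for cytotoxicity, read by MTT assay, with a stated time of 72 h (a lower number here means a stronger inhibitor, a higher number a weaker inhibitor), compound 1 gives 290 nM, and compound 2 gives 180 nM. Between them stands (fluoro in place of hydrogen on an aromatic carbon), and this made a 1.6-fold lower number from compound 1 to compound 2 (0.21 log units; within the scatter). Compound 3 `Cc1c(C(=O)Nc2ccc(Oc3ccnc4[nH]ccc34)cc2)nnn1-c1ccc(F)cc1` carries a core that differs from that of compound 1; how the two cores differ is not broken down here. In this assay compound 3 gives 180 nM. Compound 4 `Cc1c(C(=O)Nc2ccc(Oc3ccnc4[nH]ccc34)cc2)nnn1-c1ccc(F)c(F)c1` has not been measured; from compound 3 it is reached by fluoro in place of hydrogen on an aromatic carbon. This is the same kind of change as that from compound 1 to compound 2, though the surroundings are not the same: there the entering fluoro was ortho to a large group, here it is ortho to a fluoro group and meta to a large group. Because the earlier change gave a 1.6-fold lower number from compound 1 to compound 2 (0.21 log units; within the scatter), a comparable step, a 1.4-fold lower number from compound 3 to compound 4 (0.14 log units; within the scatter), is expected. Compound 4 is therefore estimated at 130 nM, likely between 60 nM and 300 nM.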

Compound 4, half-maximal inhibitory concentration: 1070 nM
Estimate against measurement, compound 4: 8.2-fold (0.92 log units) below, outside the stated range (above it).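

In this assay, the change from 4-fluorophenyl to 3,4-difluorophenyl gave a 5.9-fold higher number from compound 3 to compound 4 (0.77 log units; beyond the scatter), so the same kind of fluoro step did not carry over from one core to the other in size or in direction: the same change on two cores in this assay, a 1.6-fold lower number (0.21 log units; within the scatter) from compound 1 to compound 2 and a 5.9-fold higher number (0.77 log units; beyond the scatter) from compound 3 to compound 4, 9.6-fold (0.98 log units) apart, beyond the scatter of two such steps. For this series, then, a fluoro step read on one core cannot be taken as a guide to the same kind of step on another. It does not show what sets the two steps apart, as they differ both in the core and in the surroundings of the entering fluoro, and each rests on a single pair of compounds.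

Left open is whether a chlorine atom, a methyl group or a methoxy group entering at the same place on the ring of compound 3 would give a step like that to compound 4. Also open, as far as these compounds go, is how the 3,4-difluorophenyl group would behave on the core of compound 1.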